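A few compounds are considered here, and "the series" means these few. Any claim that something is new, unique, unknown or untested is made for them only; others in the source may bear on it.

Compound 1 `C=C1CC[C@@H]2[C@](C)(CCC[C@]2(C)C(=O)O)[C@H]1CCc1ccc2c(OC(C)=O)ccc(OC(C)=O)c2c1` and compound 2 `C=C1CC[C@@H]2[C@](C)(CCC[C@]2(C)C(=O)OC)[C@H]1CCc1ccc2c(OC(C)=O)ccc(OC(C)=O)c2c1` share one core and differ only by methyl in place of hydrogen on an oxygen next to a carbonyl group. In a functional assay on A549 cells (Homo sapiens) for cytotoxicity, read by sulforhodamine B assay, with a stated time of 72 h (a higher number here means a weaker inhibitor of growth, a lower number a stronger inhibitor of growth), compound 1 gives 240 nM, while compound 2 gives 120 nM, so the change made a 2.0-fold lower number from compound 1 to compound 2 (0.30 log units; within the scatter). Compound 3 `C=C1CC[C@@H]2[C@](C)(CCC[C@]2(C)C(=O)O)[C@H]1CCC1=CCc2c(OC(C)=O)ccc(OC(C)=O)c2C1` carries a different core; the difference between the two cores is not broken down here. In this assay compound 3 gives 2500 nM. Compound 4 `C=C1CC[C@@H]2[C@](C)(CCC[C@]2(C)C(=O)OC)[C@H]1CCC1=CCc2c(OC(C)=O)ccc(OC(C)=O)c2C1` has not yet been tested and differs from compound 3 by methyl in place of hydrogen on an oxygen next to a carbonyl group, the same change as that between compound 1 and compound 2, made at the same place. That change has been measured once before, giving a 2.0-fold lower number from compound 1 to compound 2 (0.30 log units; within the scatter). On that basis the step expected for compound 4 is a 1.9-fold lower number from compound 3 to compound 4 (0.28 log units; within the scatter). Compound 4 is therefore estimated at 1300 nM, most likely between 500 nM and 3500 nM, with the measured number still to come.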

Compound 4, concentration for 50% growth inhibition: 510 nM
Compound 4: the middle estimate sits 2.5-fold (0.41 log units) above what was measured; the measured number falls inside the stated range.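

On the core of compound 3, methyl in place of hydrogen on the oxygen of the carboxy group gives, in this assay, a 4.9-fold lower number from compound 3 to compound 4 (0.69 log units; beyond the scatter). Set beside the earlier case, the two steps do not differ by more than the usual spread of such data: the same change on two cores in this assay, a 2.0-fold lower number (0.30 log units; within the scatter) from compound 1 to compound 2 and a 4.9-fold lower number (0.69 log units; beyond the scatter) from compound 3 to compound 4, 2.5-fold (0.39 log units) apart, within the scatter of two such steps. For the compounds shown here, the size of the step on one core is thus compatible with that on the other, but this rests on only two pairs, and it gives neither a rule for other cores nor a reason for the step.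

As far as these compounds go, it remains open whether a larger ester such as an ethyl ester, or an amide, would follow the methyl ester on these two cores. From the compounds shown here alone, the role of the two acetate groups also remains open.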